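The source may report more compounds than this note shows. Statements on the series, on what has been measured and on what is new or still open speak of the compounds shown alone.

For the measured compounds named here, in an assay on CHO cells for inhibition of metabotropic glutamate receptor 1 (Rattus norvegicus) (a higher number here means a weaker inhibitor, a lower number a stronger inhibitor), compound 1 `CCCOC(=O)c1[nH]c(CO)c(C(=O)OC(C)(C)C)c1C` gives 7900 nM, the highest of the two numbers measured so far; compound 2 `Cc1c(C(=O)OC(C)C(C)(C)C)c[nH]c1C(=O)Oc1cccnc1` gives 720 nM, a gap beyond the usual scatter of the measurement. Compound 3 `CCCOC(=O)c1[nH]c(C(=O)OC)c(C(=O)OC(C)(C)C)c1C` has not yet been measured. It differs from compound 1 in one place: methoxycarbonyl in place of hydroxymethyl on an aromatic carbon. Going by the values given here, no measured pair shows this change on its own, so its direction rests on judgement alone. A small gain in potency is expected, as the step of a 2.0-fold lower number from compound 1 to compound 3 (0.30 log units; within the scatter) in this assay. Compound 3 is accordingly estimated at 4000 nM, within a range from 1000 nM to 15000 nM.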

Compound 3, half-maximal inhibitory concentration: 3200 nM
Estimate against measurement, compound 3: 1.3-fold (0.10 log units) above; the measured number falls inside the stated range.
By their numbers in this assay, from the lowest: compound 2; then compound 3; then compound 1.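

In this assay, methoxycarbonyl in place of hydroxymethyl on the aromatic carbon next to the ring nitrogen gives a 2.5-fold lower number from compound 1 to compound 3 (0.39 log units; beyond the scatter). This modest step shows that the carbon accepts the larger group, and that the hydrogen-bond donor of hydroxymethyl is not needed to keep the potency of compound 1. No available measurement accounts for the step.

As far as these compounds go, whether a carboxylic acid, a primary amide or an aminomethyl group on this carbon would lower the number further remains open. So does the effect of a longer ester chain.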